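A few compounds are considered here, and "the series" means these few. Any claim that something is new, unique, unknown or untested is made for them only; others in the source may bear on it.

Compound 1 `COc1ccc(Br)cc1-c1nc2cc(F)ccc2[nH]1` and compound 3 `COc1ccc(Br)cc1-c1nc2cc(Cl)ccc2[nH]1` share one core and differ in a single place: chloro in place of fluoro on an aromatic carbon. In an assay for inhibition of Alpha amylase (Homo sapiens), with a stated time of 10 min (on this read-out lower numbers stand for stronger inhibition and higher numbers for weaker inhibition), compound 1 gives 2600 nM, and compound 3 gives 2620 nM, so that a 1.0-fold higher number from compound 1 to compound 3 (0.00 log units; within the scatter). Compound 2 `Oc1c(Br)cc(Cl)cc1-c1nc2cc(F)ccc2[nH]1` is built on a different core; the difference between the two cores is not broken down here. In this assay compound 2 gives 2860 nM, a number that lies within the scatter of those of compound 1 and compound 3, so no order among the three can be read from it. Compound 4 `Oc1c(Br)cc(Cl)cc1-c1nc2cc(Cl)ccc2[nH]1` has not yet been measured. It arises from compound 2 by the same change that turns compound 1 into compound 3: chloro in place of fluoro on an aromatic carbon. Within the data shown here, that change, in the one pair where both ends are known, moved the number hardly at all, and the expectation is that it behaves alike here. In this assay the expected step is a 1.0-fold higher number from compound 2 to compound 4 (0.01 log units; within the scatter), beside the measured one a 1.0-fold higher number from compound 1 to compound 3 (0.00 log units; within the scatter), and the estimate rests on that measured step alone. Compound 4 is therefore expected to give about 2900 nM, within a range from 1500 nM to 5600 nM.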

Compound 4, half-maximal inhibitory concentration: 2860 nM
Compound 4: the middle estimate sits 1.0-fold (0.01 log units) above what was measured, and the stated range covers the measured number.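

In this assay, chloro in place of fluoro on a second core gives no change at the digits printed from compound 2 to compound 4 (within the scatter). Set beside the earlier step, the same change looks alike on both cores: the same change on two cores in this assay, a 1.0-fold higher number (0.00 log units; within the scatter) from compound 1 to compound 3 and no change at the digits printed (within the scatter) from compound 2 to compound 4, 1.0-fold (0.00 log units) apart, within the scatter of two such steps

This shows that, in the two pairs available, the swap from fluoro to chloro carries from one core to the other with no visible difference in the number, so the first pair was a fair guide to the second. It does not show that the change is without effect on every core in this series, and it cannot test whether a step of real size would carry over as well, since both steps here lie within the scatter.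

Among these compounds, what an amine, a carboxylic acid or a longer chain would do in the same place on the aromatic ring stays open, since fluoro and chloro are the only groups seen there. Whether the two cores would still match with such a group in that place is open too.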